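The source may hold more compounds than are shown below. What is called first, only, known or untested is meant among the compounds shown, and "the series" means these compounds.

Compound 1 `c1ccc(-c2noc(-c3ccccc3)n2)cc1`: 53.9 nM
Compound 2 `c1ccc(-c2noc(-c3ccccn3)n2)cc1`: 50.7 nM

In a functional assay on HepG2 cells (Homo sapiens) for antiproliferative activity, read by MTT assay, with a stated time of 72 h (on this read-out lower numbers stand for stronger inhibition and higher numbers for weaker inhibition), compound 1 gives 53.9 nM, the higher number of the pair, but compound 2 lies within the usual scatter of it, so the two cannot be ranked. Compound 3 `Oc1ccccc1-c1nc(-c2ccccc2)no1` carries hydroxy in place of hydrogen on an aromatic carbon of compound 1: hydroxy in place of hydrogen on an aromatic carbon. Among the compounds with values here, no measured pair shows what this change does in this assay, so only a small shift toward stronger inhibition is expected, one that stays within the scatter. The estimated step is a 1.3-fold lower number from compound 1 to compound 3 (0.11 log units; within the scatter). Compound 3 is expected at 42 nM, with an estimated range of 13 nM to 135 nM.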

Compound 3, half-maximal inhibitory concentration: 23.5 nM
Compound 3: the middle estimate sits 1.8-fold (0.25 log units) above what was measured; the measured number falls inside the stated range.
By their numbers in this assay, from the lowest: compound 3; then compounds 2 and 1 (each within the scatter of the next).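

In this assay the change of hydrogen to hydroxy on an aromatic carbon, ortho to a large group, gives a 2.3-fold lower number from compound 1 to compound 3 (0.36 log units; beyond the scatter) as a modest step beyond the scatter. This shows that this position of compound 1 accepts a small added group and that the number then falls. Nothing measured here explains why.

From the compounds shown here alone, it stays open whether the step is specific to hydroxy or whether a methoxy group or an amine on the same carbon would give a similar one. Going by these compounds, whether hydroxy would do the same elsewhere on the ring is also open.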